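A few compounds are considered here, and "the series" means these few. Any claim that something is new, unique, unknown or untested is made for them only; others in the source may bear on it.

Within the data shown here, compound 1 `C[C@@H]1CCCN1c1c(C#N)c2c(N)nc(Nc3cn[nH]c3)nc2n1C` is the stronger of the two compounds measured so far in an assay on isolated protein for binding affinity to Leucine-rich repeat serine/threonine-protein kinase 2 (Homo sapiens), read by TR-FRET and LanthaScreen, with a stated time of 2 h (on this read-out higher numbers stand for weaker inhibition and lower numbers for stronger inhibition), where compound 1 gives 0.2 nM. Among the measured compounds shown here, the only other measured compound, compound 2 `C[C@@H]1CCCN1c1cc2c(N)ncnc2n1C`, lacks both the nitrile and the aminopyrazole arm of compound 1, and in this assay compound 2 gives 164 nM, a gap that lies well beyond the usual scatter. The next compound, compound 3 `Cc1nn(C)cc1Nc1nc(N)c2c(C#N)c(N3CCC[C@H]3C)n(C)c2n1`, keeps the core of compound 1 and changes only the arm: 1,3-dimethyl-1H-pyrazol-4-yl in place of 1H-pyrazol-4-yl on a nitrogen on an aromatic ring. For the measured compounds named here, no measured pair shows this particular change, so the size of the step is uncertain. Compound 3 is expected to remain close to compound 1, with at most a modest loss, because compound 1 already stands at 0.2 nM and the change is small. The estimate for compound 3 is 0.5 nM, in a range from 0.1 nM to 3 nM, which corresponds to an expected step of a 2.5-fold higher number from compound 1 to compound 3 (0.40 log units; beyond the scatter).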

Compound 3, inhibition constant: 1 nM
Compound 3: middle estimate off by 2.0-fold (0.30 log units), on the low side; measured number inside the range.
By their numbers in this assay, from the lowest: compound 1; then compound 3; then compound 2.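

In this assay, this position on the arm proves sensitive but not critical: 1,3-dimethyl-1H-pyrazol-4-yl in place of 1H-pyrazol-4-yl gives a 5.0-fold higher number from compound 1 to compound 3 (0.70 log units; beyond the scatter), a modest step beyond the scatter. The change also takes the arm from 1 hydrogen-bond donor to 0, yet compound 3 still gives 1 nM, so a low value in this assay does not depend on the arm carrying that donor. Nothing at hand accounts for the size of this step.

The compounds shown do not separate the contributions of the two methyl groups, which a 1-methyl-1H-pyrazol-4-yl or 3-methyl-1H-pyrazol-4-yl arm on the same core would address. They also leave open how far this position accepts larger groups, such as an ethyl or cyclopropyl on the pyrazole, or an arm built on a phenyl ring instead.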